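Switching an aryl group at the ring nitrogen of a diaminopyrimidine

The source may hold more compounds than are shown below. What is called first, only, known or untested is meant among the compounds shown, and "the series" means these compounds.

Measured so far:
compound 1 `Cc1ccc(CNc2nc(Nc3ccc(N4CCN(C)CC4)cn3)ncc2Cl)cc1` with 38100 nM
compound 2 `CN1CCN(c2ccc(Nc3ncc(Cl)c(NCc4ccco4)n3)nc2)CC1` with 21300 nM

Going by the values given here, in a functional assay on MCF7 cells (Homo sapiens) for inhibition, read by CCK-8 assay, with a stated time of 48 h (on this read-out lower numbers stand for stronger inhibition of growth and higher numbers for weaker inhibition of growth), compound 2 stands beside compound 1, the only other measured compound, and the step of a 1.8-fold lower number from compound 1 to compound 2 (0.25 log units; within the scatter) separates them, so neither can be called the more active of the two. Compound 3 `COc1ccc(Nc2nc(Nc3ccc(N4CCN(C)CC4)cn3)ncc2Cl)cc1` has not yet been measured. It differs from compound 2 by 4-methoxyphenyl in place of (furan-2-yl)methyl on a nitrogen on an aromatic ring. Among the compounds with values here, only one measured step exists, and it concerns a different exchange at the same nitrogen, furan-2-yl in place of 4-methylphenyl on a saturated chain carbon; that step was a 1.8-fold lower number from compound 1 to compound 2 (0.25 log units; within the scatter). Because that sole step a 1.8-fold lower number from compound 1 to compound 2 (0.25 log units; within the scatter) stayed within the scatter, the group on this nitrogen appears to move the number little, and compound 3 is expected to show a step of about a 1.0-fold higher number from compound 2 to compound 3 (0.01 log units; within the scatter), none beyond the scatter. Compound 3 is therefore estimated at 22000 nM, within 7000 nM to 65000 nM.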

Compound 3, concentration for 50% growth inhibition: 8450 nM
The estimate for compound 3 lay 2.6-fold (0.42 log units) above the measured number; the range from low to high includes it.
By their numbers in this assay, from the lowest: compound 3; then compounds 2 and 1 (each within the scatter of the next).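

In this assay the group on this nitrogen does shift the number: 4-methoxyphenyl in place of (furan-2-yl)methyl gives a 2.5-fold lower number from compound 2 to compound 3 (0.40 log units; beyond the scatter) and 4-methoxyphenyl in place of 4-methylbenzyl gives a 4.5-fold lower number from compound 1 to compound 3 (0.65 log units; beyond the scatter) while the exchange of the two ring groups that both sit on a saturated chain carbon gave only a 1.8-fold lower number from compound 1 to compound 2 (0.25 log units; within the scatter) and stayed within the scatter. Compound 3, the only one of the three with its ring bound directly to this nitrogen, therefore has the lowest number, although the gain remains modest. Each step beyond the scatter changes the ring and removes the saturated chain carbon at once, so the compounds shown do not separate these two changes, and a 4-methoxybenzyl group or an unsubstituted phenyl on this nitrogen would be needed to tell them apart. Nothing at hand gives a reason for the shift.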